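The compounds below may be only part of what the source reports. "The series", "measured", "known", "first", "only" and "open" are said of these compounds alone.

Measured compounds in a functional assay on Huh-7 cells (Homo sapiens) for cytotoxicity, with a stated time of 48 h; a lower number here means a stronger inhibitor, a higher number a weaker inhibitor:
compound 1 `O=[N+]([O-])c1ccc(CN2CCC(n3cc(CC(OCc4cc(-c5ccccc5)no4)c4ccc(Br)cc4)nn3)CC2)cc1`: 7000 nM
compound 2 `O=[N+]([O-])c1ccc(CN2CCC(n3cc(CC(OCc4cc(-c5cccc(F)c5)no4)c4ccc(Br)cc4)nn3)CC2)cc1`: 3000 nM
compound 3 `O=[N+]([O-])c1ccc(CN2CCC(n3cc(CC(OCc4cc(-c5ccccc5F)no4)c4ccc(Br)cc4)nn3)CC2)cc1`: 2000 nM

Compound 3 gives the lowest number of the three, though the gap to compound 2 lies within the scatter; only the gap to compound 1 is beyond it. Compound 4 `COc1ccccc1-c1cc(COC(Cc2cn(C3CCN(Cc4ccc([N+](=O)[O-])cc4)CC3)nn2)c2ccc(Br)cc2)on1` differs from compound 3 by methoxy in place of fluoro on an aromatic carbon, on an aromatic carbon of a six-membered aromatic ring of carbon only, ortho to a large group. Going by the values given here, no measured step covers a methoxy here. Among the compounds with values here, the steps that bear on the site are a 3.5-fold lower number from compound 1 to compound 3 (0.54 log units; beyond the scatter) and a 1.5-fold lower number from compound 2 to compound 3 (0.18 log units; within the scatter), both modest or within scatter. A step of similar size in this assay, or none beyond the scatter, is therefore expected for compound 4, with the direction uncertain, estimated as a 1.5-fold higher number from compound 3 to compound 4 (0.18 log units; within the scatter). Compound 4 is estimated at 3000 nM, range 1200 nM to 8000 nM.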

Compound 4, half-maximal inhibitory concentration: 5000 nM
Compound 4: middle estimate off by 1.7-fold (0.22 log units), on the low side; low and high end bracket the measured number.
By their numbers in this assay, from the lowest: compounds 3, 2, 4 and 1 (each within the scatter of the next, the first and the last beyond it).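

In this assay, the site ortho to a large group proves sensitive to which group it carries, not only to whether it is substituted: a 2.5-fold higher number from compound 3 to compound 4 (0.40 log units; beyond the scatter) for methoxy in place of fluoro. Methoxy does not reproduce the step seen with fluoro, as a 1.4-fold lower number from compound 1 to compound 4 (0.15 log units; within the scatter) for methoxy in place of hydrogen stays within the scatter. a 1.7-fold higher number from compound 2 to compound 4 (0.22 log units; within the scatter) also stays within the scatter. No measured evidence accounts for the difference between fluoro and methoxy here. As far as these compounds go, whether a hydroxyl or an amine at this site would read like fluoro or like methoxy remains open.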